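The source may hold more compounds than are shown below. What is called first, only, known or untested is meant among the compounds shown, and "the series" means these compounds.

In a functional assay on MCF7 cells (Homo sapiens) for cytotoxicity, read by MTT assay, with a stated time of 48 h (on this read-out higher numbers stand for weaker inhibition and lower numbers for stronger inhibition), the measured compounds gave:
compound 1, `CCN(CC)c1ccc2cc(C(=O)c3ccc(N4CCN(C(=O)CN5CCNCC5)CC4)cc3)oc2c1`: 5340 nM
compound 2, `CCN(CC)c1ccc2cc(C(=O)c3ccc(N4CCN(C(=O)CN5CCN(C(=O)CCl)CC5)CC4)cc3)oc2c1`: a limit of the assay, > 40000 nM
compound 3, `CCN(CC)c1ccc2cc(C(=O)c3ccc(N4CCN(C(=O)CN5CCN(S(=O)(=O)c6ccc(F)cc6)CC5)CC4)cc3)oc2c1`: 20500 nM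

Among the two actual numbers, compound 3 stands highest; compound 1 lies below it, a 3.8-fold higher number from compound 1 to compound 3 (0.58 log units; beyond the scatter). Compound 2 sits at the limit (the limit of > 40000 nM in this assay, at which 1 of the 3 values shown sits). Both measured changes on the ring nitrogen raised the number: an at least 7.4-fold higher number from compound 1 to compound 2 (0.87 log units; beyond the scatter) and a 3.8-fold higher number from compound 1 to compound 3 (0.58 log units; beyond the scatter), while between the two substituted compounds an at least 1.9-fold lower number from compound 2 to compound 3 (0.29 log units; that floor lies within the scatter). Compound 4, `CCOC(=O)CN1CCN(CC(=O)N2CCN(c3ccc(C(=O)c4cc5ccc(N(CC)CC)cc5o4)cc3)CC2)CC1`, carries a third group at that same nitrogen: (ethoxycarbonyl)methyl in place of (4-fluorophenyl)sulfonyl on an amine nitrogen in a ring. Going by the values given here, no measured step separates two such groups beyond the scatter, so in this assay compound 4 is expected to stay close to compound 3, a 1.3-fold lower number from compound 3 to compound 4 (0.11 log units; within the scatter). The estimate for compound 4 is 16000 nM, within 6000 nM to 40000 nM.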

Compound 4, half-maximal inhibitory concentration: > 40000 nM
Compound 4 ended at the assay's limit; the forecaster's own chance of this, stated with the estimate: 20%; at least 2.5-fold (0.39 log units) between middle value and limit.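

In this assay compound 4 sits at a limit of the assay, not at a number: the limit of > 40000 nM in this assay, at which 2 of the 4 values shown sit.

So a group with no ring, (ethoxycarbonyl)methyl, also gives a higher number than the hydrogen on this ring nitrogen, with an at least 7.4-fold higher number from compound 1 to compound 4 (0.87 log units; beyond the scatter). All three groups shown on this nitrogen now go the same way, and none of them has a ring-free, simple form that keeps the number of compound 1. Against compound 3 the result is only an at least 1.9-fold higher number from compound 3 to compound 4 (0.29 log units; that floor lies within the scatter), and the step from compound 2 to compound 4 cannot be read.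

On these data alone, whether a plain methyl group or a short chain ending in an amine on this nitrogen would stay close to compound 1 remains open.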